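Bromine and hydroxyl added to the aryl ring of compound 2

This account rests on a few compounds, and the source may have more. Where it says the series, first, only, none or still open, it means among the compounds named here.

Measured so far:
compound 1 `COc1ccc([C@H](C)NC(=O)/C(C#N)=C/c2cccc(Br)n2)cc1`, 1200 nM
compound 2 `CCC[C@H](NC(=O)/C(C#N)=C/c1ccccc1)c1ccccc1`, 6250 nM
compound 3 `CCC[C@H](NC(=O)/C(C#N)=C/c1cccc([N+](=O)[O-])c1)c1ccccc1`, 1730 nM

In a functional assay on MM1 cells (Homo sapiens) for antiproliferative activity, read by MTT assay, with a stated time of 72 h (a lower number here means a stronger inhibitor, a higher number a weaker inhibitor), compound 2 gives the highest of the three numbers; compound 3 lies nearest, and compound 1, built on a different core, gives the lowest value of the three. Compound 4 `CCC[C@H](NC(=O)/C(C#N)=C/c1ccc(O)c(Br)c1)c1ccccc1` carries 3-bromo-4-hydroxyphenyl in place of phenyl on a double-bonded chain carbon bound to a double-bonded chain carbon. For the measured compounds named here, the one step with a bearing is a 3.6-fold lower number from compound 2 to compound 3 (0.56 log units; beyond the scatter), where a group placed on that same aryl ring moved the number down by a modest amount. Compound 4 is therefore expected to give a lower number than compound 2, by a modest step of about a 2.5-fold lower number from compound 2 to compound 4 (0.40 log units; beyond the scatter). For compound 4 the estimate in this assay is 2500 nM, within a range from 900 nM to 7000 nM.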

Compound 4, half-maximal inhibitory concentration: > 10000 nM
Compound 4: only a limit was reported; the forecaster's own chance of this, stated with the estimate: 5%; middle value at least 4.0-fold (0.60 log units) from the limit.
By their numbers in this assay, from the lowest: compounds 1 and 3 (each within the scatter of the next); then compound 2. At a limit, above all of these: compound 4.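

In this assay compound 4 reached only a limit, > 10000 nM. On these data alone, that limit gives an at least 1.6-fold higher number from compound 2 to compound 4 (0.20 log units; that floor lies within the scatter), so its true size stays unknown. Even so, this position does not answer every added group as it answered nitro in a 3.6-fold lower number from compound 2 to compound 3 (0.56 log units; beyond the scatter): 3-bromo-4-hydroxyphenyl brought no lower number, so the gain seen with nitro does not carry over to this pair of groups. Still open, as far as these compounds go, is which of the two, bromine or hydroxyl, sets this result, and what an amine or a carboxylic acid on the same ring would do.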